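A Trifluoromethyl Group Added to Compound 3

A few compounds are considered here, and "the series" means these few. Any claim that something is new, unique, unknown or untested is made for them only; others in the source may bear on it.

In a functional assay on COLO 205 cells (Homo sapiens) for inhibition, read by sulforhodamine B assay (on this read-out higher numbers stand for weaker inhibition of growth and lower numbers for stronger inhibition of growth), compound 3 `Cc1ccc2[nH]c(-c3ccc(-c4ccc(-c5ccccc5)cc4)cc3)nc2c1` gives 2560 nM and stands within the scatter of compound 1 `COc1ccc(-c2ccc(-c3ccc(-c4nc5cc(C)ccc5[nH]4)cc3)cc2)cc1OC` at 2320 nM in this small set. Compound 2 `FC(F)(F)c1ccc(-c2ccc(-c3ccc(-c4nc5ccccc5[nH]4)cc3)cc2)cc1` gives a clearly higher 33900 nM on a slightly different core. Compound 4 `Cc1ccc2[nH]c(-c3ccc(-c4ccc(-c5ccc(C(F)(F)F)cc5)cc4)cc3)nc2c1` carries trifluoromethyl in place of hydrogen on an aromatic carbon, para to a large group trifluoromethyl in place of hydrogen on an aromatic carbon and so turns phenyl into 4-(trifluoromethyl)phenyl. For the measured compounds named here, the one measured step at this phenyl a 1.1-fold higher number from compound 1 to compound 3 (0.04 log units; within the scatter) stayed within the scatter and hints at little change. Yet compound 2 already holds 4-(trifluoromethyl)phenyl, and its 33900 nM points towards weaker inhibition. The expected step is a 3.1-fold higher number from compound 3 to compound 4 (0.49 log units; beyond the scatter) in that direction. For compound 4 the estimated value is 8000 nM with a range from 2200 nM to 30000 nM as a rough expectation.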

Compound 4, concentration for 50% growth inhibition: 30600 nM
The estimate for compound 4 lay 3.8-fold (0.58 log units) below the measured number, and the stated range ends below it.
By their numbers in this assay, from the lowest: compounds 1 and 3 (each within the scatter of the next); then compounds 4 and 2 (each within the scatter of the next).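

In this assay, this position proves sensitive: a 12-fold higher number from compound 3 to compound 4 (1.08 log units; beyond the scatter) is a large step towards weaker inhibition of growth, whereas the earlier change at the same phenyl stayed within the scatter. a 13-fold higher number from compound 1 to compound 4 (1.12 log units; beyond the scatter) is also large, so the two compounds without trifluoromethyl lie well apart from compound 4. With 4-(trifluoromethyl)phenyl in place, the methyl on the core makes no clear difference: a 1.1-fold lower number from compound 2 to compound 4 (0.04 log units; within the scatter) stays within the scatter.

From the compounds shown here alone, whether an amine or a carboxylic acid at this position would keep growth inhibition remains open. Nothing available explains why trifluoromethyl gives this large step.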